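The compounds below may be only part of what the source reports. "The series", "measured", "known", "first", "only" and "open" are said of these compounds alone.

The study concerns two measured compounds built on a shared core and one that has not yet been measured. Compound 1, of structure `CC(C)=CCC1Cc2c(OCc3ccccc3)cc(=O)n(CCCO)c2CC1(C)C`, was tested in a functional assay on PANC-1 cells (Homo sapiens) for inhibition, read by MTT assay, with a stated time of 24 h, tested at 10 uM (on this read-out lower numbers stand for less inhibition and higher numbers for more inhibition at the one concentration tested (going by the name of the read-out)), where compound 1 gives 11.1%. Compound 2, of structure `CCOc1cc(=O)n(CCCO)c2c1CC(C/C=C(\C)CCC=C(C)C)C(C)(C)C2`, stands lowest of the two numbers: in this assay compound 2 gives 0.8%, and its nearest neighbour is compound 1, a gap that lies beyond the scatter.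

The step now followed leads from compound 2 to compound 3, of structure `CC(C)=CCC/C(C)=C/CC1Cc2c(OCc3ccccc3)cc(=O)n(CCCO)c2CC1(C)C`. The change is a single one: phenyl in place of methyl on a saturated chain carbon bound to an oxygen on an aromatic ring. Cut one bond further out, it reads ethoxy to benzyloxy.

Nothing in the data gives a step between measured compounds that differ in one place, so the size of this step can only be judged from the two numbers in hand. Because compound 2 gives 0.8% and compound 1 gives 11.1%, the step from compound 2 to compound 3 is expected to be a modest rise, a number 7.2 percentage points higher from compound 2 to compound 3 (within the scatter), near the edge of the scatter. For compound 3 the estimated inhibition is 8%, with a range from 0% to 20%.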

Compound 3, a percentage reported as inhibition, at one concentration (the size of the read-out at that concentration, not a potency): 1.5%
Beside the measured number, compound 3's estimate is 6.5 percentage points above it; the measured number falls inside the stated range.
By their numbers in this assay, from the lowest: compounds 2, 3 and 1 (each within the scatter of the next, the first and the last beyond it).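

In this assay, phenyl in place of methyl on a saturated chain carbon bound to an oxygen on an aromatic ring, which reads as ethoxy to benzyloxy, gives a number 0.7 percentage points higher from compound 2 to compound 3 (within the scatter), so at this place the two groups cannot be told apart on this read-out. The second single change, 3-methylbut-2-en-1-yl in place of hydrogen on a saturated chain carbon bound to a double-bonded chain carbon, gives a number 9.6 percentage points lower from compound 1 to compound 3 (within the scatter), and this pair cannot be told apart either, so neither change on its own is shown to shift the read-out beyond the usual scatter. No independent measurement is at hand that would account for either step.

The compounds shown carry only methyl and phenyl at the saturated chain carbon bound to the oxygen, so it remains open how an amine, a carboxylic acid or a longer chain would read at that place. Each comparison also rests on one concentration in one cell line, so these steps say nothing about how the same changes would read at other concentrations or in other cells.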